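This account rests on a few compounds, and the source may have more. Where it says the series, first, only, none or still open, it means among the compounds named here.

Of the compounds shown here, three sharing one core have so far been tested in an assay on CHO cells for displacement of a labelled ligand from adenosine receptor A3 (Homo sapiens), read by scintillation counting, tested at 10 uM; on this read-out lower numbers stand for less inhibition and higher numbers for more inhibition at the one concentration tested (going by the name of the read-out). Compound 1 `CC(C)(C)Cc1c(-c2ccoc2)sc(N)c1C(=O)c1ccc(Cl)cc1` gives 1%. Compound 2 `CC(C)(C)Cc1c(-c2cccnc2)sc(N)c1C(=O)c1ccc(Cl)cc1` gives 1% in this assay. Compound 3 `CC(C)(C)Cc1c(-c2ccc(F)cc2F)sc(N)c1C(=O)c1ccc(Cl)cc1` gives 1% in this assay. Compound 3 thus stands level with the other two: the step of no change at the digits printed from compound 1 to compound 3 (within the scatter) and the step of no change at the digits printed from compound 2 to compound 3 (within the scatter) both lie within the scatter, as does the step of no change at the digits printed from compound 1 to compound 2 (within the scatter). Each of these steps exchanges the aromatic group sitting on the same aromatic carbon of the core, and none of them moves the read-out.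

Compound 4 `CC(C)(C)Cc1c(-c2ccc(Cl)cc2)sc(N)c1C(=O)c1ccc(Cl)cc1` has not yet been measured. It differs from compound 3 by a single exchange: 4-chlorophenyl in place of 2,4-difluorophenyl on an aromatic carbon. All three measured steps bear on this exchange, since each swaps one ring for another on that same aromatic carbon, and each came out flat. A fourth ring there is expected to behave alike, so the step of a number 2 percentage points higher from compound 3 to compound 4 (within the scatter) is expected to be none beyond the scatter. Compound 4 is therefore estimated at 3% in this assay, with a range from 0% to 15%.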

Compound 4, a percentage reported as inhibition, at one concentration (the size of the read-out at that concentration, not a potency): 1%
Beside the measured number, compound 4's estimate is 2 percentage points above it; the measured number falls inside the stated range.
By their numbers in this assay, from the lowest: compounds 1, 2, 3 and 4 (each within the scatter of the next).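

On the aromatic carbon next to the ring sulfur, a 4-chlorophenyl group reads the same in this assay as each of the three earlier rings: there is no change at the digits printed from compound 3 to compound 4 (within the scatter) and no change at the digits printed from compound 2 to compound 4 (within the scatter) and also no change at the digits printed from compound 1 to compound 4 (within the scatter) on this read-out. The flat picture therefore now extends to a ring bearing a single chlorine, alongside the furan-3-yl, pyridin-3-yl and 2,4-difluorophenyl rings, and none of the four stands apart from the others. No available evidence accounts for this flat result.

From the compounds shown here alone, all four compounds carry an aromatic ring at this position, so it remains open whether a non-ring group there, such as an amine, a carboxylic acid or a longer alkyl chain, would give a different reading. The neopentyl, amino and (4-chlorophenyl)carbonyl groups stay the same throughout, which leaves their contribution open as well.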